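Swapping a styryl arm for a dimethoxyphenyl ring

The source may report more compounds than this note shows. Statements on the series, on what has been measured and on what is new or still open speak of the compounds shown alone.

Of the compounds shown here, two built on one shared core have been tested in a functional assay on SF-295 cells (Homo sapiens) for antiproliferative activity, with a stated time of 48 h; on this read-out lower numbers stand for higher toxicity in this test and higher numbers for lower toxicity in this test. Compound 1 `Cc1cc(O)c(C2=NN(c3ccc(S(N)(=O)=O)cc3)C(c3ccccc3O)C2)cc1Cl` gives 8090 nM in this assay. For the measured compounds named here, compound 2 `Cc1cc(O)c(C2=NN(c3ccc(S(N)(=O)=O)cc3)C(/C=C/c3ccccc3)C2)cc1Cl` gives 37300 nM, the highest of the two numbers; the single known step, a 4.6-fold higher number from compound 1 to compound 2 (0.66 log units; beyond the scatter), separates it from compound 1. Compound 3 `COc1ccc(C2CC(c3cc(Cl)c(C)cc3O)=NN2c2ccc(S(N)(=O)=O)cc2)cc1OC` has not yet been measured. It differs from compound 2 in one place: 3,4-dimethoxyphenyl in place of 2-phenylethenyl on a saturated ring carbon. Going by the values given here, no measured step covers this exact exchange. Among the compounds with values here, the only step that bears on it is a 4.6-fold higher number from compound 1 to compound 2 (0.66 log units; beyond the scatter), in which an aromatic ring on a saturated ring carbon gave the lower number and the 2-phenylethenyl group the higher one. Since compound 3 again carries an aromatic ring on that saturated ring carbon, a move back toward a lower number is expected, roughly a 2.5-fold lower number from compound 2 to compound 3 (0.40 log units; beyond the scatter). For compound 3 the expected value in this assay is 15000 nM, within a range from 5000 nM to 45000 nM.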

Compound 3, concentration lethal to 50% of the cells: 340 nM
The estimate for compound 3 lay 44-fold (1.64 log units) above the measured number; measured number outside the range, below it.
By their numbers in this assay, from the lowest: compound 3; then compound 1; then compound 2.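

At the saturated ring carbon of the shared core, this assay responds far more strongly than the earlier pair suggested, with a 110-fold lower number from compound 2 to compound 3 (2.04 log units; beyond the scatter) when 3,4-dimethoxyphenyl replaces 2-phenylethenyl. Having an aromatic ring at this position does not by itself set the number: 2-hydroxyphenyl and 3,4-dimethoxyphenyl are both such rings, yet there is a 24-fold lower number from compound 1 to compound 3 (1.38 log units; beyond the scatter), so what the ring carries matters here. Nothing shown explains why these exchanges move the number so far.

On these data alone, it remains open whether both methoxy groups are needed, or whether a phenyl ring with a single methoxy group at either place would give a similarly low number. Also unresolved is whether larger ethoxy groups, or an amine in place of a methoxy group, would keep or lose this toxicity.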